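Ethyl extension on the amine chain, chloro versus methyl

The source may report more compounds than this note shows. Statements on the series, on what has been measured and on what is new or still open speak of the compounds shown alone.

Four compounds share one core and are assessed in a functional assay on the whole organism for inhibition, with Mus musculus as the target; a higher number here means that more compound is needed for the effect, a lower number that less compound is needed. Compound 1 `CCNCC(=O)Nc1cccc2c1CN(C)CC2c1ccc(Cl)cc1` gives 24 mg/kg. Compound 2 `CCCCNCC(=O)Nc1cccc2c1CN(C)CC2c1ccc(Cl)cc1` gives 13.5 mg/kg. Compound 3 `CCNCC(=O)Nc1cccc2c1CN(C)CC2c1ccc(C)cc1` gives about 45 mg/kg. Compound 4 `CCCCNCC(=O)Nc1cccc2c1CN(C)CC2c1ccc(C)cc1` has no number yet.

The change from compound 1 to compound 2 is ethyl in place of hydrogen on a saturated chain carbon, two bonds along the chain from an amine nitrogen, and it made a 1.8-fold lower number from compound 1 to compound 2 (0.25 log units; within the scatter). The same change, at the same place, separates compound 3 from compound 4: ethyl in place of hydrogen on a saturated chain carbon, two bonds along the chain from an amine nitrogen. The two cores differ by methyl in place of chloro on an aromatic carbon, which made a 1.9-fold higher number from compound 1 to compound 3 (0.27 log units; within the scatter). Compound 2 and compound 3 are separated by a gap beyond the scatter, with compound 2 at the lower number; no other ordering among the three is supported.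

Going by the values given here, for compound 4 a step like a 1.8-fold lower number from compound 3 to compound 4 (0.26 log units; within the scatter) is expected, resting on the single earlier instance of the change, because compound 1 to compound 2 gave a 1.8-fold lower number from compound 1 to compound 2 (0.25 log units; within the scatter). The estimate for compound 4 in this assay is 25 mg/kg, with an expected range from 12 mg/kg to 50 mg/kg.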

Compound 4, dose for half-maximal effect: 34 mg/kg
Compound 4: the middle estimate sits 1.4-fold (0.13 log units) below what was measured, within the range that was stated.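

In this assay, the ethylamino to butylamino change on the methyl core gives a 1.3-fold lower number from compound 3 to compound 4 (0.12 log units; within the scatter), and this step cannot be told apart from its counterpart on the chloro core: the same change on two cores in this assay, a 1.8-fold lower number (0.25 log units; within the scatter) from compound 1 to compound 2 and a 1.3-fold lower number (0.12 log units; within the scatter) from compound 3 to compound 4, 1.3-fold (0.13 log units) apart, within the scatter of two such steps. Methyl in place of chloro on an aromatic carbon, read with butylamino in place, gives a 2.5-fold higher number from compound 2 to compound 4 (0.40 log units; beyond the scatter), and this step also agrees with its earlier counterpart, so within these four compounds each change carries from one core to the other without a detectable difference: the same change on two cores in this assay, a 1.9-fold higher number (0.27 log units; within the scatter) from compound 1 to compound 3 and a 2.5-fold higher number (0.40 log units; beyond the scatter) from compound 2 to compound 4, 1.3-fold (0.13 log units) apart, within the scatter of two such steps. This does not show that the chain change has an effect of its own, since both of its steps lie within the scatter, and two pairs of compounds cannot establish a rule for the wider series.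

On these data alone, whether the same agreement holds for a longer chain than butylamino or for a cyclic amine remains open. So does whether it holds with fluoro, methoxy or trifluoromethyl in place of chloro on the aromatic carbon.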